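The source may report more compounds than this note shows. Statements on the series, on what has been measured and on what is new or still open speak of the compounds shown alone.

Compound 1 `CC(C)c1n[nH]c2c(NCc3ccc(-c4ccccn4)cc3)nc(SCC3CNC(=O)O3)nc12`, compound 2 `CC(C)c1n[nH]c2c(NCc3ccc(-c4ccccn4)cc3)nc(SCC(O)CN3CCNCC3)nc12` and compound 3 `CC(C)c1n[nH]c2c(NCc3ccc(-c4ccccn4)cc3)nc(SCC(C)(C)N)nc12` share one core and differ only in the chain on a sulfur. In a functional assay on HT cells (Homo sapiens) for antiproliferative activity, read by fluorescence, with a stated time of 72 h (on this read-out higher numbers stand for weaker inhibition of growth and lower numbers for stronger inhibition of growth), compound 3 gives 85 nM, compound 1 gives 80 nM and compound 2 gives 332 nM. Compound 3 therefore stands level with compound 1, as a 1.1-fold higher number from compound 1 to compound 3 (0.03 log units; within the scatter) shows, while a 3.9-fold lower number from compound 2 to compound 3 (0.59 log units; beyond the scatter) sets it clearly apart from compound 2.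

Compound 4 `CC(C)c1n[nH]c2c(NCc3ccc(-c4ccccn4)cc3)nc(S)nc12` loses the chain altogether: hydrogen in place of 2-amino-2-methylpropyl on a sulfur. The measured steps only swap one chain for another, so none of them shows a sulfur without a chain. The largest, a 4.2-fold higher number from compound 1 to compound 2 (0.62 log units; beyond the scatter), is the best available guide to size. Within the data shown here, compound 2 is the only compound clearly apart from compound 3, and its number is higher, so a modest rise seems more likely than a fall.

In this assay the expected step is a 2.9-fold higher number from compound 3 to compound 4 (0.47 log units; beyond the scatter). Compound 4 is estimated at 250 nM, with an expected range from 70 nM to 900 nM.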

Compound 4, concentration for 50% growth inhibition: 2760 nM
Compound 4: the middle estimate sits 11-fold (1.04 log units) below what was measured; measured number outside the range, above it.
By their numbers in this assay, from the lowest: compounds 1 and 3 (each within the scatter of the next); then compound 2; then compound 4.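

Taking the chain off the sulfur moves the number more than any swap of one chain for another, and this holds for all three chains: 2-amino-2-methylpropyl (a 32-fold higher number from compound 3 to compound 4 (1.51 log units; beyond the scatter)), (2-oxo-1,3-oxazolidin-5-yl)methyl (a 35-fold higher number from compound 1 to compound 4 (1.54 log units; beyond the scatter)) and 2-hydroxy-3-(piperazin-1-yl)propyl (an 8.3-fold higher number from compound 2 to compound 4 (0.92 log units; beyond the scatter)). In this assay, then, having one of these chains on the sulfur counts for more than which of the three it is, and no compound shown goes against this. The data offer no measured explanation for the rise.

Going by these compounds, what stays open is how little of a chain is enough: a single methyl group on the sulfur would separate the effect of any carbon substituent from that of a full chain. A short chain ending in a carboxylic acid would show whether the end group matters at all.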